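The compounds below may be only part of what the source reports. "The series", "measured", "known", "first", "only" and "open" are said of these compounds alone.

Going by the values given here, compound 3 `O=C(CCCCCCc1ccccc1)c1ncc(-c2cncnc2)o1` gives 22 nM in an assay (Rattus norvegicus) for inhibition of Fatty-acid amide hydrolase 1 (Homo sapiens) (a higher number here means a weaker inhibitor, a lower number a stronger inhibitor), the second highest of the three numbers so far: compound 1 `Nc1ccc(-c2cnc(C(=O)CCCCCCc3ccccc3)o2)cc1` gives 90 nM, and compound 2 `COc1ccnc(-c2cnc(C(=O)CCCCCCc3ccccc3)o2)c1` gives 0.8 nM. Every measured step swaps one aromatic group for another at the same aromatic carbon of the shared core: a 110-fold lower number from compound 1 to compound 2 (2.05 log units; beyond the scatter), a 4.1-fold lower number from compound 1 to compound 3 (0.61 log units; beyond the scatter) and a 28-fold higher number from compound 2 to compound 3 (1.44 log units; beyond the scatter). Compound 4 `O=C(CCCCCCc1ccccc1)c1ncc(C(=O)C(F)(F)F)o1` differs from compound 3 by (trifluoromethyl)carbonyl in place of pyrimidin-5-yl on an aromatic carbon. Among the compounds with values here, no measured step exchanges an aromatic ring for a carbonyl group, so the earlier steps show only that changes at this carbon move this assay by large amounts in either direction. Compound 4 is expected to differ by a 2.2-fold lower number from compound 3 to compound 4 (0.34 log units; beyond the scatter), with wide uncertainty. The estimate for compound 4 is 10 nM, somewhere between 1 nM and 150 nM.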

Compound 4, inhibition constant: 4 nM
Compound 4: middle estimate off by 2.5-fold (0.40 log units), on the high side, and the stated range covers the measured number.
By their numbers in this assay, from the lowest: compound 2; then compound 4; then compound 3; then compound 1.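

In this assay, a group with no ring at this carbon gives a number within the range of the aromatic groups: a 5.5-fold lower number from compound 3 to compound 4 (0.74 log units; beyond the scatter) and a 23-fold lower number from compound 1 to compound 4 (1.35 log units; beyond the scatter), but a 5.0-fold higher number from compound 2 to compound 4 (0.70 log units; beyond the scatter). Among these compounds, then, an aromatic ring at this carbon is not needed for a low number, though 4-methoxypyridin-2-yl still gives a lower number than (trifluoromethyl)carbonyl. Nothing given here explains these steps. On these data alone, whether the trifluoromethyl or the carbonyl part carries the step stays open, as does whether an acetyl group or a carboxylic acid on this carbon would give a similar number.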